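Removing one methoxy group from compound 3

The source may report more compounds than this note shows. Statements on the series, on what has been measured and on what is new or still open speak of the compounds shown alone.

Compound 1 `CC(C)c1noc(-c2ccc(C3=NCCN3)cc2)n1` gives 230 nM in an assay for inhibition of Amine oxidase [flavin-containing] B (Homo sapiens), read by fluorescence and spectrophotometry, using microsomes, with stated times of 30 min and 20 min; a lower number here means a stronger inhibitor, a higher number a weaker inhibitor. Compound 2 `c1ccc(OCc2noc(-c3ccc(C4=NCCN4)cc3)n2)cc1` gives 9980 nM, and a 43-fold higher number from compound 1 to compound 2 (1.64 log units; beyond the scatter), the change being a phenoxymethyl in place of isopropyl on an aromatic carbon. Compound 3 `COc1ccc(-c2noc(-c3ccc(C4=NCCN4)cc3)n2)cc1OC` gives 756 nM, the second highest of the three numbers; compound 1 lies nearer to it than compound 2 does. Compound 4 `COc1cccc(-c2noc(-c3ccc(C4=NCCN4)cc3)n2)c1` differs from compound 3 by hydrogen in place of methoxy on an aromatic carbon. Going by the values given here, the single measured step concerns a different part of the shared core, so no measured step speaks directly to the loss of a methoxy group. Compound 4 is therefore expected to show only a 1.3-fold higher number from compound 3 to compound 4 (0.12 log units; within the scatter), within the scatter. The estimate for compound 4 is 1000 nM, in a range from 400 nM to 3000 nM.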

Compound 4, half-maximal inhibitory concentration: 216 nM
For compound 4 the middle estimate is 4.6-fold (0.67 log units) above the measured one; the measured number lies below the stated range.
By their numbers in this assay, from the lowest: compounds 4 and 1 (each within the scatter of the next); then compound 3; then compound 2.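

In this assay, hydrogen in place of the methoxy group that is para to a large group gives a 3.5-fold lower number from compound 3 to compound 4 (0.54 log units; beyond the scatter) and so shows that this methoxy group is not neutral: compound 3 loses to its simpler partner. The 3-methoxyphenyl group in place of phenoxymethyl gives a 46-fold lower number from compound 2 to compound 4 (1.66 log units; beyond the scatter) but in place of isopropyl gives a 1.1-fold lower number from compound 1 to compound 4 (0.03 log units; within the scatter) and so leaves compound 4 level with compound 1. Nothing available explains these steps. As far as these compounds go, whether a fluorine or a hydroxyl group at this position would match hydrogen stays open, as does the effect of removing the other methoxy group.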